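Replacing cyano with chloro in compound 2

The compounds below may be only part of what the source reports. "The series", "measured", "known", "first", "only" and "open" are said of these compounds alone.

Within the data shown here, in a functional assay on MC-38 cells (Mus musculus) for antiproliferative activity (a higher number here means a weaker inhibitor, a lower number a stronger inhibitor), compound 2 (`COc1ccc(S(=O)(=O)Nc2cccc3c(C#N)c[nH]c23)cc1`) gives 0.17 ug/mL, the lowest number measured so far. Compound 1 (`COc1ccc(S(=O)(=O)Nc2cccc3cc[nH]c23)cc1`) gives 1.5 ug/mL. Compound 3 (`N#Cc1c[nH]c2c(NS(=O)(=O)c3ccc(C(=O)O)cc3)cccc12`) reads > 100 ug/mL, which is a limit of the assay. Compound 4 (`COc1ccc(S(=O)(=O)Nc2cccc3c(Cl)c[nH]c23)cc1`) has chloro in place of cyano on an aromatic carbon. The most relevant evidence concerns this same carbon, where cyano replaced hydrogen in an 8.8-fold lower number from compound 1 to compound 2 (0.95 log units; beyond the scatter), a modest step. The large step of an at least 580-fold higher number from compound 2 to compound 3 (2.76 log units; beyond the scatter) changed a different group, so it bears little on this swap. Chloro is expected to keep most of the gain seen with cyano, so the expected step is small: a 1.5-fold higher number from compound 2 to compound 4 (0.17 log units; within the scatter). For compound 4, the estimate is 0.25 ug/mL, with an expected range of 0.07 ug/mL to 1 ug/mL.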

Compound 4, half-maximal inhibitory concentration: 0.2 ug/mL
Estimate against measurement, compound 4: 1.3-fold (0.10 log units) above; low and high end bracket the measured number.
By their numbers in this assay, from the lowest: compounds 2 and 4 (each within the scatter of the next); then compound 1. At a limit, above all of these: compound 3.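

In this assay, with a 1.2-fold higher number from compound 2 to compound 4 (0.07 log units; within the scatter), chloro and cyano on this carbon cannot be told apart. With a 7.5-fold lower number from compound 1 to compound 4 (0.88 log units; beyond the scatter), the gain over hydrogen proves not to be tied to the nitrile: a single chlorine, with no triple bond and no hydrogen-bond acceptor, does the same. Nothing measured here explains why these two groups read alike. As far as these compounds go, whether an amine, a methyl group or a longer chain on this carbon would keep the gain remains open.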